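From 2-cyanobenzyl to 2-bromobenzyl: notes on compound 4

This account rests on a few compounds, and the source may have more. Where it says the series, first, only, none or still open, it means among the compounds named here.

In a functional assay on HepG2 cells (Homo sapiens) for antiproliferative activity, read by MTT assay, with a stated time of 24 h (on this read-out lower numbers stand for stronger inhibition and higher numbers for weaker inhibition), compound 1 `COc1cc(OC)c(-c2coc3cc(OCc4ccc([N+](=O)[O-])cc4)ccc3c2=O)cc1OC` gives 2500 nM and compound 2 `COc1cc(OC)c(-c2coc3cc(OCc4ccccc4C(F)(F)F)ccc3c2=O)cc1OC` gives 6550 nM.

Compound 3 `COc1cc(OC)c(-c2coc3cc(OCc4ccccc4C#N)ccc3c2=O)cc1OC` gives > 10000 nM, which is a limit and not a number. Its standing in the series rests on (the limit of > 10000 nM in this assay, at which 1 of the 3 values shown sits).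

Compound 4 `COc1cc(OC)c(-c2coc3cc(OCc4ccccc4Br)ccc3c2=O)cc1OC` carries bromo in place of cyano on an aromatic carbon, ortho to a large group (bromo in place of cyano on an aromatic carbon). Among the measured compounds shown here, no measured step brings in bromo, so the evidence is indirect.

Two measured steps replace the 4-nitrophenyl of compound 1: a 2.6-fold higher number from compound 1 to compound 2 (0.42 log units; beyond the scatter) with 2-(trifluoromethyl)phenyl, and an at least 4.0-fold higher number from compound 1 to compound 3 (0.60 log units; beyond the scatter) with 2-cyanophenyl. For the measured compounds named here, the closest precedent is the exchange on the same aromatic carbon, an at least 1.5-fold higher number from compound 2 to compound 3 (0.18 log units; that floor lies within the scatter), and its floor lies within the scatter.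

Going by the values given here, with compound 2 at 6550 nM as the only number for a non-cyano group on that carbon, compound 4 is expected to fall near it. A modest move towards lower numbers is therefore expected, although a result at the limit remains possible.

The estimated step is an at least 1.4-fold lower number from compound 3 to compound 4 (0.15 log units; that floor lies within the scatter).

For compound 4, the expected value is 7000 nM, with an estimated range of 3000 nM to 16000 nM.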

Compound 4, half-maximal inhibitory concentration: 2180 nM
Beside the measured number, compound 4's estimate is 3.2-fold (0.51 log units) above it; the measured number lies below the stated range.
By their numbers in this assay, from the lowest: compounds 4 and 1 (each within the scatter of the next); then compound 2. At a limit, above all of these: compound 3.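

Compound 2 and compound 3 had both given higher numbers than compound 1, which left open whether any group on this aromatic carbon would cost activity in this assay; bromo shows that it need not, with a 1.1-fold lower number from compound 1 to compound 4 (0.06 log units; within the scatter), so compound 4 and compound 1 stand level. The same carbon now also separates its groups by a measured step, a 3.0-fold lower number from compound 2 to compound 4 (0.48 log units; beyond the scatter), for bromo in place of trifluoromethyl, whereas the earlier exchange on this carbon gave only a floor within the scatter, and bromo in place of cyano gives an at least 4.5-fold lower number from compound 3 to compound 4 (0.66 log units; beyond the scatter). Compound 3 remains a limit and not a number, so that last step is only a floor and its true size stays unknown: the limit of > 10000 nM in this assay, at which 1 of the 4 values shown sits.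

The compounds shown do not tell whether the gain follows bromo itself or would also appear with chloro, iodo or methoxy on the same carbon, and they offer no unsubstituted benzyl as a reference for the 2-substituted groups. Going by these compounds, how an amine or a carboxylic acid would read out on this carbon also remains open.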